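A few compounds are considered here, and "the series" means these few. Any claim that something is new, unique, unknown or untested is made for them only; others in the source may bear on it.

For the measured compounds named here, in a functional assay on SMMC-7721 cells (Homo sapiens) for cytotoxicity, read by MTT assay, with a stated time of 24 h (on this read-out higher numbers stand for weaker inhibition and lower numbers for stronger inhibition), compound 1 (`CN1C/C(=C\c2ccc(C(F)(F)F)cc2)C(=O)/C(=C/c2cccnc2)C1`) gives 4830 nM and holds the lower of the two numbers measured, with compound 2 (`CN1C/C(=C\c2ccc(C#N)cc2)C(=O)/C(=C/c2cccnc2)C1`) at 13600 nM as its only neighbour. Compound 3 (`CN1C/C(=C\c2ccncc2)C(=O)/C(=C/c2ccc(C(F)(F)F)cc2)C1`) carries pyridin-4-yl in place of pyridin-3-yl on a double-bonded chain carbon bound to a double-bonded ring carbon. Going by the values given here, the single measured step (a 2.8-fold higher number from compound 1 to compound 2 (0.45 log units; beyond the scatter)) was modest and changed a different group, and no measurement covers the pyridine swap. No shift beyond the usual scatter is therefore expected in this assay here. The expected step (a 1.1-fold higher number from compound 1 to compound 3 (0.06 log units; within the scatter)) is small. Compound 3 is estimated at 5500 nM with an expected range from 2000 nM to 15000 nM in this read-out.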

Compound 3, half-maximal inhibitory concentration: 17700 nM
Beside the measured number, compound 3's estimate is 3.2-fold (0.51 log units) below it; measured number outside the range, above it.
By their numbers in this assay, from the lowest: compound 1; then compounds 2 and 3 (each within the scatter of the next).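

The two groups have the same atoms and the same counts, yet in this assay the swap gives a 3.7-fold higher number from compound 1 to compound 3 (0.56 log units; beyond the scatter). At this place, on a double-bonded chain carbon bound to a double-bonded ring carbon, the way the pyridine is attached therefore matters, even with no atom gained or lost. Nothing available here explains this shift. Still open, as far as these compounds go, is how pyridin-2-yl or a plain phenyl ring would read at this place. Also open, from the compounds shown here alone, is whether the swap gives a similar step when nitrile replaces trifluoromethyl.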